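Compound 2 and a change from fluoro to trifluoromethyl

This account rests on a few compounds, and the source may have more. Where it says the series, first, only, none or still open, it means among the compounds named here.

compound 1 `O=C1/C(=C/c2cccnc2)CN(S(=O)(=O)c2ccc(Cl)cc2)C/C1=C\c1ccccc1F`: 12100 nM
compound 2 `O=C1/C(=C/c2cccnc2)CN(S(=O)(=O)c2ccc(Br)cc2)C/C1=C\c1ccccc1F`: 12800 nM
compound 3 `N#Cc1ccc(S(=O)(=O)N2C/C(=C\c3cccnc3)C(=O)/C(=C/c3ccccc3F)C2)cc1`: 15800 nM

These three values come from a functional assay on QGY-7703 cells (Homo sapiens) for cytotoxicity, read by MTT assay, with a stated time of 24 h; on this read-out lower numbers stand for stronger inhibition and higher numbers for weaker inhibition. Compound 2 cannot be separated from the other two compounds: the data show a 1.1-fold higher number from compound 1 to compound 2 (0.02 log units; within the scatter) and a 1.2-fold higher number from compound 2 to compound 3 (0.09 log units; within the scatter). Compound 4 `O=C1/C(=C/c2cccnc2)CN(S(=O)(=O)c2ccc(Br)cc2)C/C1=C\c1ccccc1C(F)(F)F` differs from compound 2 by one exchange, trifluoromethyl in place of fluoro on an aromatic carbon. The measured steps bear on this only indirectly. Together with a 1.3-fold higher number from compound 1 to compound 3 (0.12 log units; within the scatter), they all exchange the chloro, bromo and cyano groups at another place in the molecule. For the measured compounds named here, no measured compound carries anything other than fluoro at the place that changes here, so the data offer no direct guide. With nothing measured to suggest a shift, no step beyond the scatter is expected in this assay, and the estimate stays close to compound 2 at 12800 nM. The expected step is a 1.1-fold lower number from compound 2 to compound 4 (0.03 log units; within the scatter). For compound 4 the estimated value is 12000 nM, with an expected range from 5500 nM to 26000 nM.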

Compound 4, half-maximal inhibitory concentration: 5510 nM
Compound 4: middle estimate off by 2.2-fold (0.34 log units), on the high side; low and high end bracket the measured number.
By their numbers in this assay, from the lowest: compound 4; then compounds 1, 2 and 3 (each within the scatter of the next).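

In this assay, the exchange of fluoro for trifluoromethyl on the aromatic carbon gives a 2.3-fold lower number from compound 2 to compound 4 (0.37 log units; beyond the scatter), a modest step and the only one shown that lies beyond the scatter. The earlier compounds shown here varied chloro, bromo and cyano at another place and stayed within the scatter of each other, whereas going from 2-fluorophenyl to 2-(trifluoromethyl)phenyl moves the number. No evidence at hand bears on why the number falls at this position.

On these data alone, a single exchange here defines no trend, so it remains open whether a methyl group, a methoxy group or an amine at this place would give a similar number. As far as these compounds go, it also remains open whether trifluoromethyl would give a similar step with chloro or cyano in place of bromo at the other place.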